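Cytotoxicity series: bromo in place of fluoro

The source may hold more compounds than are shown below. What is called first, only, known or untested is meant among the compounds shown, and "the series" means these compounds.

Compound 2 `CCOC(=O)CCCCCOc1cccc(CN(C(=O)c2ccc(-c3cccc(F)c3)cc2)C(C)C)c1` gives in an ADME assay on Raji cells (Homo sapiens) for cytotoxicity, read by CellTiter-Glo and resazurin assay, with a stated time of 72 h (on this read-out lower numbers stand for an effect already at smaller amounts and higher numbers for an effect only at larger amounts of compound), only a limit, > 26000 nM. Compound 1 `CCOC(=O)CCCCCOc1cccc(CN(C(=O)c2ccc(-c3ccco3)cc2)C(C)C)c1` likewise reaches only a limit in this assay, > 26000 nM. Among the measured compounds shown here, the step that the two limits leave unreadable from compound 1 to compound 2 thus cannot be read, and the limit of > 26000 nM in this assay, at which 2 of the 2 values shown sit, is the sole evidence on it. Compound 3 `CCOC(=O)CCCCCOc1cccc(CN(C(=O)c2ccc(-c3cccc(Br)c3)cc2)C(C)C)c1` differs from compound 2 by bromo in place of fluoro on an aromatic carbon. No readable measured step bears on this change, so no shift beyond the scatter is expected in this assay. Compound 3 is therefore expected to sit near the limit again, estimated at 30000 nM in the range 10000 nM to 100000 nM. The implied step that the limit leaves unreadable from compound 2 to compound 3 is expected to stay within the scatter.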

Compound 3, half-maximal effective concentration: > 26000 nM
Compound 3 was reported as a limit; the forecaster's own chance of this, stated with the estimate: 80%; the middle value does not contradict the limit.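

Among the compounds shown here, compound 3 gives only a limit, > 26000 nM, in this assay, so no step among compound 1, compound 2 and compound 3 can be read. Still open, from the compounds shown here alone, is whether furan-2-yl, 3-fluorophenyl and 3-bromophenyl differ at all in this assay.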